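A few compounds are considered here, and "the series" means these few. Any claim that something is new, unique, unknown or untested is made for them only; others in the source may bear on it.

Of the compounds shown here, three have been measured. Compound 1 `COc1ccc(C(F)(F)F)cc1S(=O)(=O)Nc1cccnc1` gives in an assay on isolated protein for inhibition of alkaline phosphatase, tissue-nonspecific isozyme (Homo sapiens) (on this read-out higher numbers stand for weaker inhibition and lower numbers for stronger inhibition), a value of 183 nM. Compound 2 `COc1ccc(Cl)cc1S(=O)(=O)Nc1cncc(-c2ccc(Cl)cc2)c1` gives 198 nM in this assay. Compound 3 `COc1ccc(Cl)cc1S(=O)(=O)Nc1cncc(-c2cccnc2)c1` gives 73 nM, the lowest of the three numbers; its step to compound 1 and its step to compound 2 are both beyond the scatter, so compound 3 is the strongest inhibitor so far. Among the compounds with values here, the only single-site step measured runs a 2.7-fold lower number from compound 2 to compound 3 (0.43 log units; beyond the scatter), which shows that changing the group at this place moves the number by a modest amount.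

Compound 4 `COc1ccc(Cl)cc1S(=O)(=O)Nc1cncc(C(=O)O)c1` differs from compound 3 by carboxy in place of pyridin-3-yl on an aromatic carbon. Within the data shown here, no measured compound carries a carboxy group, so nothing bears directly on this change; the step from compound 2 to compound 3 shows only that the group at this place matters. Exchanging a ring for a small acid is a larger change than that step, and a weakening beyond the scatter is expected, with wide uncertainty. Compound 4 is therefore estimated to give 350 nM in this assay, between 60 nM and 2000 nM, which means an expected step of a 4.8-fold higher number from compound 3 to compound 4 (0.68 log units; beyond the scatter).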

Compound 4, half-maximal inhibitory concentration: 134 nM
Estimate against measurement, compound 4: 2.6-fold (0.42 log units) above, and the stated range covers the measured number.
By their numbers in this assay, from the lowest: compounds 3, 4, 1 and 2 (each within the scatter of the next, the first and the last beyond it).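

In this assay, carboxy in place of pyridin-3-yl gives a 1.8-fold higher number from compound 3 to compound 4 (0.26 log units; within the scatter), and carboxy in place of 4-chlorophenyl gives a 1.5-fold lower number from compound 2 to compound 4 (0.17 log units; within the scatter). Within the data shown here, until now this position, on an aromatic carbon two atoms from the ring nitrogen, had been seen only with six-membered aromatic rings, and the one step between them, a 2.7-fold lower number from compound 2 to compound 3 (0.43 log units; beyond the scatter), showed only that the choice of ring could move the number. Compound 4 shows that the ring is not required for a number in this range: a carboxy group with no ring, 3 heavy atoms and 1 hydrogen-bond donor stays within the scatter of both ring-bearing compounds, even though those two lie beyond the scatter of each other.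

The compounds shown offer no measurement that explains this result.

They leave open whether a primary amide, a methyl ester or a hydroxymethyl group at this position would stay within the scatter of the carboxy compound, and whether a longer acid such as carboxymethyl would do the same. They also leave open how a simple amine would compare here, and whether carboxy would give a similar number if the chlorine on the other ring were replaced by trifluoromethyl.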